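The source may report more compounds than this note shows. Statements on the series, on what has been measured and on what is new or still open speak of the compounds shown alone.

Working notes on the series.

Compound 1 `COc1ncnc2c1c(-c1ccsc1)cn2[C@@H]1O[C@H](CO)[C@@H](O)[C@H]1O` gives 140 nM in a functional assay on HCT-116 cells (Homo sapiens), read by MTT assay, with a stated time of 72 h (on this read-out higher numbers stand for weaker inhibition and lower numbers for stronger inhibition), and stands lowest of the two numbers measured; its nearest neighbour is compound 2 `C#Cc1cn([C@@H]2O[C@H](CO)[C@@H](O)[C@H]2O)c2ncnc(OC)c12`, which gives 5140 nM. Among the measured compounds shown here, the one step measured so far, a 37-fold higher number from compound 1 to compound 2 (1.56 log units; beyond the scatter), exchanges the thiophen-3-yl for ethynyl on an aromatic carbon and is large.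

Compound 3 `CSc1ncnc2c1c(-c1ccsc1)cn2[C@@H]1O[C@H](CO)[C@@H](O)[C@H]1O` differs from compound 1 at another place: methylsulfanyl in place of methoxy on an aromatic carbon. For the measured compounds named here, no measured step changes this position, so the step from compound 1 to compound 2 does not bear on it directly; it only shows that the shared core tolerates change without losing the low number in this assay.

Going by the values given here, with no direct precedent, a small step, if any, is expected within the scatter, as a 1.3-fold lower number from compound 1 to compound 3 (0.10 log units; within the scatter). For compound 3 the value in this assay is estimated at 110 nM, with a range from 30 nM to 400 nM.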

Compound 3, half-maximal inhibitory concentration: > 20000 nM
Compound 3: no number, only a limit (the forecaster's own chance of this, stated with the estimate: 2%); at least 180-fold (2.25 log units) between middle value and limit.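

This position, untouched by any earlier step, turns out to be sensitive in this assay: with thiophen-3-yl and the rest of the structure kept, methylsulfanyl in place of methoxy on the aromatic carbon next to the ring nitrogen gives an at least 140-fold higher number from compound 1 to compound 3 (2.15 log units; beyond the scatter). Compound 3 gives > 20000 nM, which is a limit and not a number. The step is therefore only a minimum, because one of its ends is that limit: the limit of > 20000 nM in this assay, at which 1 of the 3 values shown sits.

On these data alone, what an amine or a longer chain such as ethoxy would give at this position stays open, so one cannot yet say whether methoxy is specifically favoured or methylsulfanyl alone is disfavoured. Also open, as far as these compounds go, is whether the same exchange would have a comparable effect with ethynyl in place of thiophen-3-yl.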